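The source may hold more compounds than are shown below. What is called first, only, known or untested is meant among the compounds shown, and "the series" means these compounds.

In a functional assay on MV4-11 cells (Homo sapiens) for cytotoxicity (on this read-out lower numbers stand for stronger inhibition and higher numbers for weaker inhibition), compound 1 `CC(=O)N1CCC(c2ccc(Nc3nc(N)n(-c4ccccn4)n3)cc2)C1` gives 1 nM and compound 2 `CN1CCN(c2ccc(Nc3nc(N)n(-c4ccccn4)n3)cc2)CC1` gives 2 nM, two numbers within the scatter of each other. Compound 3 `CN1CCC(c2cccc(Nc3nc(N)n(-c4ccccn4)n3)c2)CC1` is reported only as a limit, < 1 nM. The step followed here leads to compound 4 `CN1CCC(c2ccc(Nc3nc(N)n(-c4ccccn4)n3)cc2)CC1`, with 1-methylpiperidin-4-yl in place of 1-acetylpyrrolidin-3-yl on an aromatic carbon, para to a large group: 1-methylpiperidin-4-yl in place of 1-acetylpyrrolidin-3-yl on an aromatic carbon. For the measured compounds named here, the one measured step at this place, a 2.0-fold higher number from compound 1 to compound 2 (0.30 log units; within the scatter), also removes 1-acetylpyrrolidin-3-yl, putting 4-methylpiperazin-1-yl there, and it stays within the scatter. No step beyond the scatter is therefore expected in this assay, and the estimated step is a 1.2-fold higher number from compound 1 to compound 4 (0.08 log units; within the scatter). Compound 4 is expected at 1.2 nM, with an estimated range of 0.5 nM to 3 nM.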

Compound 4, half-maximal inhibitory concentration: 0.3 nM
Compound 4: the middle estimate sits 4.0-fold (0.60 log units) above what was measured; the measured number lies below the stated range.
By their numbers in this assay, from the lowest: compound 4; then compounds 1 and 2 (each within the scatter of the next).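

This position is not indifferent to the group it carries, although the earlier pair showed no step beyond the scatter. In this assay, 1-methylpiperidin-4-yl gives a modest gain over 1-acetylpyrrolidin-3-yl (a 3.3-fold lower number from compound 1 to compound 4 (0.52 log units; beyond the scatter)) and over 4-methylpiperazin-1-yl (a 6.7-fold lower number from compound 2 to compound 4 (0.82 log units; beyond the scatter)). The second step is the larger one as printed, and it keeps a six-membered non-aromatic ring in place.

Compound 3 is reported only as a limit, so its place against compound 4 cannot be read: the limit of < 1 nM in this assay, at which 1 of the 4 values shown sits. On these data alone, whether the gain belongs to the ring size or to the group on its nitrogen stays open, and 1-acetylpiperidin-4-yl or an unsubstituted piperidin-4-yl would bear on this.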